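This account rests on a few compounds, and the source may have more. Where it says the series, first, only, none or still open, it means among the compounds named here.

The three compounds measured so far in an ADME assay on SW480 cells (Homo sapiens) for cytotoxicity, read by MTT assay, with a stated time of 72 h (a higher number here means a weaker inhibitor of growth, a lower number a stronger inhibitor of growth), are:

Compound 1 `CCOC(=O)c1cn[nH]c1NC(=O)C1C(C(=O)O)[C@@H]2CC[C@H]1O2` — 10000 nM
Compound 2 `O=C(O)C1C(C(=O)NCCCc2ccccc2)[C@H]2CC[C@@H]1O2` — 10000 nM
Compound 3 `O=C(O)C1C(C(=O)NCC2Cc3ccsc3CO2)[C@H]2CC[C@@H]1O2` — 10000 nM

All three share the same bicyclic core carrying a free carboxylic acid and an amide, and they differ only in the group attached to the amide nitrogen. On the numbers shown, compound 2 stands level with compound 1 and compound 3: none of the three is separated from another by more than the usual scatter, so no order can be read among them.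

Compound 4 `O=C(O)CCCNC(=O)C1C(C(=O)O)[C@@H]2CC[C@H]1O2` keeps the core of compound 2 and changes only the far end of the chain on the amide nitrogen: carboxy in place of phenyl on a saturated chain carbon, three bonds along the chain from an amide-type nitrogen. For the measured compounds named here, the measured set gives no step between two compounds that differ in a single place, so there is nothing to measure this kind of change against. Given that compounds 1, 2 and 3 with quite different amide substituents all sit at the same value, the expectation is for no step beyond the scatter, no change at the digits printed from compound 2 to compound 4 (within the scatter), and compound 4 is estimated at 10000 nM, with a range from 5000 nM to 20000 nM.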

Compound 4, concentration for 50% growth inhibition: 10000 nM
Compound 4: the middle estimate sits on the measured number at the digits printed; the measured number falls inside the stated range.
By their numbers in this assay, from the lowest: compounds 1, 2, 3 and 4 (each within the scatter of the next).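

For the compounds shown here, this is the only step in the set that changes a single place, and in this assay it reads no change at the digits printed from compound 2 to compound 4 (within the scatter) for carboxy in place of phenyl. At this position on the chain, on a saturated chain carbon, three bonds along the chain from an amide-type nitrogen, the aromatic ring can therefore be exchanged for a group with a hydrogen-bond donor and acceptor without the number leaving the scatter. Nothing measured here explains this result.

On these data alone, whether an amine or a longer chain at this same place would also stay level with compound 4 at 10000 nM remains open. Also open, as far as these compounds go, is whether any change to the group on the amide nitrogen can shift the reading in this assay at all.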